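The source may hold more compounds than are shown below. What is called first, only, known or untested is meant among the compounds shown, and "the series" means these compounds.

Measured so far:
compound 1 `CCCCCc1nc(N)n(CC(=O)Nc2ccccc2)c1-c1ccccc1Br` — 26400 nM
compound 2 `CCCCCCc1nc(N)n(CC(=O)Nc2ccccc2)c1-c1ccccc1Br` — 5700 nM
compound 3 `CCCCCCCc1nc(N)n(CC(=O)Nc2ccccc2)c1-c1ccccc1Br` — 9200 nM

In a functional assay on A-375 cells (Homo sapiens) for antiproliferative activity, read by MTT assay, with a stated time of 48 h (on this read-out higher numbers stand for weaker inhibition and lower numbers for stronger inhibition), compound 3 stands second highest of the three numbers: a 1.6-fold higher number from compound 2 to compound 3 (0.21 log units; within the scatter), whereas a 2.9-fold lower number from compound 1 to compound 3 (0.46 log units; beyond the scatter). Compound 4 `Nc1nc(CC2CC2)c(-c2ccccc2Br)n1CC(=O)Nc1ccccc1` differs from compound 3 by cyclopropyl in place of hexyl on a saturated chain carbon bound to an aromatic carbon. Going by the values given here, no measured step covers a ring in place of an open chain; the nearest evidence is chain length, where a 4.6-fold lower number from compound 1 to compound 2 (0.67 log units; beyond the scatter) and a 2.9-fold lower number from compound 1 to compound 3 (0.46 log units; beyond the scatter) both show the shortest chain giving the highest number. From the compounds shown here alone, the change to compound 4 shortens the chain well past that of compound 1, so the expectation is a higher number, with considerable uncertainty since the ring itself is untested. Compound 4 is estimated at 20000 nM (range 6000 nM to 60000 nM), the expected step being a 2.2-fold higher number from compound 3 to compound 4 (0.34 log units; beyond the scatter).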

Compound 4, half-maximal inhibitory concentration: 5800 nM
For compound 4 the middle estimate is 3.4-fold (0.54 log units) above the measured one, and the stated range ends above it.
By their numbers in this assay, from the lowest: compounds 2, 4 and 3 (each within the scatter of the next); then compound 1.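

In this assay a ring at this place reads level with the longer open chains: cyclopropyl in place of hexyl gives (a 1.6-fold lower number from compound 3 to compound 4 (0.20 log units; within the scatter)) and cyclopropyl in place of pentyl gives (a 1.0-fold higher number from compound 2 to compound 4 (0.01 log units; within the scatter)). Cyclopropyl in place of butyl gives (a 4.6-fold lower number from compound 1 to compound 4 (0.66 log units; beyond the scatter)), so the difference from compound 1 does not require a longer open chain. No measurement here bears on why the ring matches those chains.

Still open, from the compounds shown here alone, is whether a cyclobutyl or cyclohexyl ring at this place reads the same as cyclopropyl. Also open, going by these compounds, is how an amine or a carboxylic acid on this chain would read against compound 4.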